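Removing the Side Chain on the Ring Nitrogen

A few compounds are considered here, and "the series" means these few. Any claim that something is new, unique, unknown or untested is made for them only; others in the source may bear on it.

Compound 2 `Cn1c(Cc2nn(CCC=O)c(=O)c3ccccc23)nnc1SCCCCCCCC(=O)Nc1ccc(Cl)cc1Cl` carries a 2-formylethyl group on an aromatic nitrogen of the shared core. Going by the values given here, in an assay on 32D cells for inhibition of interleukin-15 (Mus musculus), read by resazurin assay, with stated times of 30 min and 2.5 days, in the presence of a further agent that is not named here (on this read-out lower numbers stand for stronger inhibition and higher numbers for weaker inhibition), compound 2 gives 8900 nM, the only full number among the two measured compounds. Compound 1 `Cn1c(Cc2nn(CCCO[Si](C)(C)C(C)(C)C)c(=O)c3ccccc23)nnc1SCCCCCCCC(=O)Nc1ccc(Cl)cc1Cl` carries the longer silyl ether chain in the same place. In this assay compound 1 reaches only a limit, > 30000 nM. The step of an at least 3.3-fold lower number from compound 1 to compound 2 (0.52 log units; beyond the scatter) is thus known only through (the limit of > 30000 nM in this assay, at which 1 of the 2 values shown sits). Compound 3 `Cn1c(Cc2n[nH]c(=O)c3ccccc23)nnc1SCCCCCCCC(=O)Nc1ccc(Cl)cc1Cl` differs from compound 2 by hydrogen in place of 2-formylethyl on an aromatic nitrogen. Among the compounds with values here, only the step from compound 1 to compound 2 bears on this change, and it shows that a shorter substituent on this nitrogen went with a lower number; whether removing it altogether continues in the same direction cannot be read from two compounds, so no more than a modest change is expected in this assay. Compound 3 is estimated at 6000 nM, within 1500 nM to 25000 nM, which means an expected step of a 1.5-fold lower number from compound 2 to compound 3 (0.17 log units; within the scatter).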

Compound 3, half-maximal inhibitory concentration: > 30000 nM
Compound 3: only a limit was reported; the forecaster's own chance of this, stated with the estimate: 20%; middle value at least 5.0-fold (0.69 log units) away from the limit.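

In this assay, hydrogen in place of 2-formylethyl on the aromatic nitrogen gives an at least 3.3-fold higher number from compound 2 to compound 3 (0.52 log units; beyond the scatter), so the lower number seen on shortening the chain does not carry through to removing it. Among the three compounds, a full number appears only with the 2-formylethyl group of compound 2, while the longer silyl ether chain of compound 1 and the bare hydrogen of compound 3 both end in a limit. The step between compound 1 and compound 3 cannot be read, as both values are limits: the limit of > 30000 nM in this assay, at which 2 of the 3 values shown sit.

The compounds shown do not separate the carbonyl of the 2-formylethyl group from the chain that carries it. As far as these compounds go, how a plain propyl chain, a 3-hydroxypropyl chain or a chain ending in an amine would stand on this nitrogen remains open.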